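Tetrazole in Place of the Sulfonamide on the Shared Core

The source may hold more compounds than are shown below. What is called first, only, known or untested is meant among the compounds shown, and "the series" means these compounds.

Among the compounds with values here, compound 1 `CCN(CC)C(=O)c1ccc(NC(=O)C(C)(O)C(F)(F)F)cc1` is the weakest point of the series so far; in an assay on a protein complex (Cavia porcellus) with sulfonylurea receptors; K-ATP channels (Homo sapiens) as the target (a lower number here means a stronger inhibitor, a higher number a weaker inhibitor), compound 1 gives only a limit, > 30000 nM. Compound 2 `CCN(CC)S(=O)(=O)c1ccc(NC(=O)C(C)(O)C(F)(F)F)cc1` is the sulfonamide analogue and gives 810 nM in this assay. The step of an at least 37-fold lower number from compound 1 to compound 2 (1.56 log units; beyond the scatter) is the only measured step, and compound 2 therefore holds the only number shown; the other value is a limit, (the limit of > 30000 nM in this assay, at which 1 of the 2 values shown sits). Compound 3 `CC(O)(C(=O)Nc1ccc(-c2nn[nH]n2)cc1)C(F)(F)F` carries the change (2H-tetrazol-5-yl in place of diethylsulfamoyl on an aromatic carbon), so the same position on the shared core is altered again, though neither the carbamoyl of compound 1 nor the sulfamoyl of compound 2 is retained. Within the data shown here, the one measured step bears on it only loosely: it shows that this position moves the number strongly, but gives no direction for a tetrazole. The expected step is therefore a 4.9-fold higher number from compound 2 to compound 3 (0.69 log units; beyond the scatter), toward a weaker number with wide uncertainty. Compound 3 is estimated at 4000 nM in this assay, with a range from 400 nM to 30000 nM.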

Compound 3, half-maximal inhibitory concentration: > 30000 nM
Compound 3: only a limit was reported; the forecaster's own chance of this, stated with the estimate: 30%; middle value at least 7.5-fold (0.87 log units) from the limit.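

In this assay, putting 2H-tetrazol-5-yl in place of diethylsulfamoyl on an aromatic carbon gives an at least 37-fold higher number from compound 2 to compound 3 (1.56 log units; beyond the scatter). The low number of compound 2 therefore does not carry over to every group at this place on the shared core: the five-membered aromatic ring with 4 hetero atoms loses the whole of the gain seen with the sulfamoyl group, at least as far as this read-out can follow it. Of the three groups now compared, only diethylsulfamoyl gives a number rather than a limit, and the step between compound 1 and compound 3 cannot be read, so the carbamoyl and tetrazole compounds cannot be ranked against each other: the limit of > 30000 nM in this assay, at which 2 of the 3 values shown sit.

The compounds shown leave open whether the number at this place depends on the sulfonyl unit itself or also on its two ethyl groups, which a piperidine-1-sulfonyl or a dimethylsulfamoyl group at the same carbon would separate. They also leave open how a carboxylic acid or a methylsulfonyl group there would compare with compound 2.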